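The source may report more compounds than this note shows. Statements on the series, on what has been measured and on what is new or still open speak of the compounds shown alone.

Of the compounds shown here, two have been measured in a functional assay on CHO cells for agonist activity at Free fatty acid receptor 2 (Homo sapiens), read by cAMP accumulation (on this read-out lower numbers stand for stronger inhibition and higher numbers for weaker inhibition), so far. Compound 1, `CC(C)[C@H](C(=O)Nc1ncc(C(N)=O)s1)c1ccc(Cl)cc1`, gives 71000 nM in this assay. Compound 2, `CCC[C@H](C(=O)Nc1nccs1)c1ccc(Cl)cc1`, gives 5500 nM in this assay, the lower of the two numbers, and the gap between compound 1 and compound 2 lies beyond the usual scatter. The two structures differ in more than one place, so no single step can be read from them; only the two numbers stand side by side.

Compound 3, `C=CC[C@H](C(=O)Nc1nccs1)c1ccc(Cl)cc1`, has not yet been measured in this assay. It differs from compound 2 in one place: vinyl in place of ethyl on a saturated chain carbon, two bonds along the chain from an aromatic carbon and a carbonyl carbon. The chain keeps the same number of heavy atoms and gains one double bond, and nothing changes on the amide or on the ring it carries.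

Going by the values given here, no measured pair shows the effect of such a change, so no direction can be taken from the data. The expectation is that compound 3 stays close to compound 2, with a step of no change at the digits printed from compound 2 to compound 3 (within the scatter) that does not go beyond the scatter. Compound 3 is therefore estimated at 5500 nM in this assay, within a range from 2200 nM to 14000 nM.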

Compound 3, half-maximal inhibitory concentration: 1100 nM
Compound 3: middle estimate off by 5.0-fold (0.70 log units), on the high side; the whole stated range lies above it.
By their numbers in this assay, from the lowest: compound 3; then compound 2; then compound 1.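

Going by these compounds alone, this is the first single change that can be read in this assay: vinyl in place of ethyl on a saturated chain carbon, two bonds along the chain from an aromatic carbon and a carbonyl carbon, gives a 5.0-fold lower number from compound 2 to compound 3 (0.70 log units; beyond the scatter), a modest step but one beyond the usual scatter. The number at this position can therefore move without the chain gaining any heavy atoms, since the only difference counted between the two groups is one double bond, and the amide and the ring it carries stay the same. Nothing measured here accounts for the shift, so it stands as an observation about this one pair, with no cause attached.

As far as these compounds go, it remains open how far the group on this carbon can be varied: an ethynyl group or a longer chain such as butenyl could lower the number further or raise it again, and one pair gives no direction for either. From the compounds shown here alone, it is also open whether the same swap would give a similar step in a compound carrying a primary amide on the ring, as compound 1 does.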